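Fluoro in Place of Methoxy: From Compound 3 to Compound 4

This account rests on a few compounds, and the source may have more. Where it says the series, first, only, none or still open, it means among the compounds named here.

Compound 1 `O=C(/C=C\Nc1ccc(F)cc1)c1nc(-c2ccc(F)cc2)n2ccccc12` gives 16900 nM in a functional assay on BT-474 cells (Homo sapiens) for cytotoxicity, read by MTT assay, with a stated time of 48 h; on this read-out lower numbers stand for stronger inhibition and higher numbers for weaker inhibition.
Compound 2 `COc1ccc(-c2nc(C(=O)/C=C\Nc3ccc4[nH]ccc4c3)c3ccccn23)cc1` gives 13000 nM in this assay.
Compound 3 `COc1ccc(N/C=C\C(=O)c2nc(-c3ccc(OC)cc3)n3ccccc23)cc1` gives 15400 nM in this assay.

The three measured numbers lie within the usual scatter of one another, so compound 3 does not stand apart from compound 1 or compound 2 in this assay. Among the measured compounds shown here, the one measured step that touches the same part of the shared core is a 1.2-fold higher number from compound 2 to compound 3 (0.07 log units; within the scatter), a change of the group on the amine nitrogen that left the number within the scatter.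

Compound 4 `COc1ccc(-c2nc(C(=O)/C=C\Nc3ccc(F)cc3)c3ccccn23)cc1` differs from compound 3 by fluoro in place of methoxy on an aromatic carbon. For the measured compounds named here, no measured step isolates this exchange; compound 1 carries the same fluoro-bearing ring on its amine nitrogen but differs elsewhere as well, and its value and that of compound 3 sit within the scatter of each other. On this basis compound 4 is expected to show no step beyond the scatter, a 1.0-fold lower number from compound 3 to compound 4 (0.01 log units; within the scatter). The estimate for compound 4 in this assay is 15000 nM, with a range from 7000 nM to 32000 nM.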

Compound 4, half-maximal inhibitory concentration: > 30000 nM
Compound 4 was reported as a limit (the forecaster's own chance of this, stated with the estimate: 10%); middle value at least 2.0-fold (0.30 log units) from the limit.
By their numbers in this assay, from the lowest: compounds 2, 3 and 1 (each within the scatter of the next). At a limit, above all of these: compound 4.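

Compound 4 is reported only as a limit in this assay: the limit of > 30000 nM in this assay, at which 1 of the 4 values shown sits. Read as floors, the step of an at least 2.3-fold higher number from compound 2 to compound 4 (0.36 log units; beyond the scatter) is beyond the scatter, whereas the floors of an at least 1.9-fold higher number from compound 3 to compound 4 (0.28 log units; that floor lies within the scatter) and an at least 1.7-fold higher number from compound 1 to compound 4 (0.24 log units; that floor lies within the scatter) lie within it, so those two exchanges of fluoro and methoxy cannot yet be given a size. The group on the amine nitrogen, which in a 1.2-fold higher number from compound 2 to compound 3 (0.07 log units; within the scatter) left the number within the scatter, therefore now shows a step beyond the scatter, with 4-fluorophenyl in place of 1H-indol-5-yl.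

As far as these compounds go, how far the true number of compound 4 lies past its limit stays open, and with it the real size of all three steps. Also open, from the compounds shown here alone, is how an amine, a hydroxyl or a carboxylic acid would read on that same aromatic carbon.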